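The compounds below may be only part of what the source reports. "The series", "measured", "known", "first", "only" and "open" are said of these compounds alone.

Compound 1 `C[C@H]1CCC(=NNc2ccccc2)c2ncc(C(=O)O)c(=O)n21`: 0.3 umol/kg; 54.8 umol/kg (2 entries)
Compound 2 `CC1CC/C(=N\Nc2ccccc2F)c2ncc(C(=O)O)c(=O)n21`: 5 umol/kg
Compound 3 `CCOc1ccc(N/N=C2\CC[C@@H](C)n3c2ncc(C(=O)O)c3=O)cc1`: 0.2 umol/kg

In a functional assay on the whole organism for inhibition, with Rattus norvegicus as the target (on this read-out lower numbers stand for an effect already at smaller amounts and higher numbers for an effect only at larger amounts of compound), compound 2 gives 5 umol/kg, the higher of the two single numbers; compound 3 gives 0.2 umol/kg, and the gap between them lies beyond the usual scatter. Compound 1 does not give a single number, since the several entries of compound 1 in this assay, 0.3 umol/kg; 54.8 umol/kg (2 entries) spread widely. Compound 4 `Cc1cccc(N/N=C2\CCC(C)n3c2ncc(C(=O)O)c3=O)c1` is not yet measured. Compound 4 differs from compound 2 in one place: 3-methylphenyl in place of 2-fluorophenyl on an amine nitrogen. For the measured compounds named here, with no measured step of this kind to lean on, the expected step from compound 2 to compound 4 is a 2.5-fold lower number from compound 2 to compound 4 (0.40 log units; beyond the scatter), downward and modest, near the edge of the scatter. Compound 4 is estimated at 2 umol/kg, within 0.3 umol/kg to 15 umol/kg, in this assay.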

Compound 4, dose for 50% inhibition: 0.4 umol/kg
Estimate against measurement, compound 4: 5.0-fold (0.70 log units) above, within the range that was stated.
By their numbers in this assay, from the lowest: compounds 3 and 4 (each within the scatter of the next); then compound 2.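

The aryl group on the amine nitrogen proved to be a sensitive position in this assay: with 3-methylphenyl in place of 2-fluorophenyl, the step is a 13-fold lower number from compound 2 to compound 4 (1.10 log units; beyond the scatter). For the compounds shown here, this is the first measured step at this position, and it is large. Because the swap alters both the substituent and its printed place on the ring, the step cannot assign the gain to either alone.

Open, going by these compounds, is how 3-fluorophenyl or 2-methylphenyl would read on that nitrogen. Compound 1 offers no firm reference: the several entries of compound 1 in this assay, 0.3 umol/kg; 54.8 umol/kg (2 entries)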